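Removing a fluorine from a benzophenone ester

The source may report more compounds than this note shows. Statements on the series, on what has been measured and on what is new or still open speak of the compounds shown alone.

Of the compounds shown here, two of the same family have already been measured. Compound 1 `Cc1ccc(C(=O)Oc2ccc(C)cc2C(=O)c2ccccc2)cc1` carries a methyl on its ester aryl ring and no fluorine on the ketone aryl ring; in a functional assay on the whole organism (strain Albino) for inhibition, with Rattus norvegicus as the target, read by paw edema (a lower number here means that less compound is needed, a higher number that more compound is needed for the effect), compound 1 gives 75.5 mg/kg. Compound 2 `Cc1ccc(OC(=O)c2ccccc2)c(C(=O)c2cccc(F)c2)c1` carries a fluoro on the ketone aryl ring and no methyl on the ester ring; in this assay compound 2 gives 75.5 mg/kg, which stands level with compound 1 at the digits shown, within the scatter, so no order can be drawn between the two.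

Compound 3 `Cc1ccc(OC(=O)c2ccccc2)c(C(=O)c2ccccc2)c1` is the next one to be measured. Its difference from compound 2 is hydrogen in place of fluoro on an aromatic carbon, a hydrogen in place of fluoro on an aromatic carbon, meta to a large group. Among the measured compounds shown here, no measured pair in this set differs by this change alone, so the size of the step is open. Given that compound 1 and compound 2 stand level in this assay while differing in two places, a step no larger than the scatter is expected from compound 2 to compound 3, a 1.0-fold lower number from compound 2 to compound 3 (0.00 log units; within the scatter). The estimated value for compound 3 in this assay is 75 mg/kg, expected between 40 mg/kg and 140 mg/kg.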

Compound 3, dose for half-maximal effect: 78.6 mg/kg
The estimate for compound 3 lay 1.0-fold (0.02 log units) below the measured number, and the stated range covers the measured number.
By their numbers in this assay, from the lowest: compounds 1, 2 and 3 (each within the scatter of the next).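

Read on its own, the exchange of fluoro for hydrogen on this aromatic carbon, meta to a large group, gives a 1.0-fold higher number from compound 2 to compound 3 (0.02 log units; within the scatter) in this assay, so the fluoro is not needed to keep the number at this level. The exchange of methyl for hydrogen on an aromatic carbon of the ester ring gives a 1.0-fold higher number from compound 1 to compound 3 (0.02 log units; within the scatter), so compound 3, which carries neither group, stands level with both compound 1 and compound 2 and serves as the unsubstituted reference that the earlier pair lacked. Nothing in hand explains why these exchanges leave the numbers level.

What the compounds shown leave open is whether this tolerance extends beyond fluoro and methyl: an amine, a carboxylic acid or a longer chain on the same aromatic carbon might or might not stay level with compound 3. All three compounds stand within the scatter of one another in this assay, so they do not yet show which part of the shared core this number depends on.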